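Working notes: truncation of compound 1 to compound 3

This account rests on a few compounds, and the source may have more. Where it says the series, first, only, none or still open, it means among the compounds named here.

Measured so far in an ADME assay on GES1 cells (Homo sapiens) for inhibition, read by MTT assay, with a stated time of 72 h; a higher number here means a weaker inhibitor, a lower number a stronger inhibitor:
- compound 1 `Cc1cc(Nc2cc(-c3ccccc3)[nH]n2)n2nc(SCc3c(Cl)cccc3Cl)nc2n1` gives 39600 nM
- compound 2 `Cc1cc(Nc2cc(-c3ccc(Cl)cc3)[nH]n2)n2nc(SCc3ccc(Br)cc3)nc2n1` gives 28200 nM

Compound 1 gives the highest of the two numbers in this assay, but compound 2 sits within the scatter of it, so the two values show no real order. Compound 3 `Cc1cc(Nc2cc(-c3ccccc3)[nH]n2)n2ncnc2n1` has not been measured. It differs from compound 1 in one place: hydrogen in place of (2,6-dichlorobenzyl)sulfanyl on an aromatic carbon. Within the data shown here, no measured pair in this small set separates the contribution of the (2,6-dichlorobenzyl)sulfanyl group, so the size of the step is a judgement from the two values only. The step from compound 1 to compound 3 is expected to be modest and toward a higher number, that is weaker inhibition, and it may well stay within the scatter: a 2.0-fold higher number from compound 1 to compound 3 (0.31 log units; beyond the scatter). Compound 3 is estimated at 80000 nM in this assay, with a range from 30000 nM to 200000 nM.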

Compound 3, half-maximal inhibitory concentration: > 50000 nM
Compound 3: no number, only a limit; the forecaster's own chance of this, stated with the estimate: 30%; the middle value lies beyond the limit too.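

In this assay compound 3 gives > 50000 nM, which is a limit of the assay and not a number. Hydrogen in place of (2,6-dichlorobenzyl)sulfanyl on this aromatic carbon gives an at least 1.2-fold higher number from compound 1 to compound 3 (0.10 log units; that floor lies within the scatter), so this first view of the position without a sulfanyl group shows no move toward a lower number, something neither earlier compound could show. The true size of the step cannot be read beyond that floor: the limit of > 50000 nM in this assay, at which 1 of the 3 values shown sits.

The compounds shown leave open whether the benzyl ring, the two chlorine atoms or the sulfur carries any contribution at this position. Also open, as far as these compounds go, is where a methylsulfanyl group, an amine or a carboxylic acid on this aromatic carbon would fall in this assay.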